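Swapping the arylidene end of a thiosemicarbazone

This account rests on a few compounds, and the source may have more. Where it says the series, first, only, none or still open, it means among the compounds named here.

Compound 1 `COc1ccc(/C=N\NC(=S)NC(C)(C)CCC[C@](C)(O)[C@@H]2CC=C(C)CC2)cc1` gives 22100 nM in a functional assay on UACC-62 cells (Homo sapiens) for cytotoxicity, read by sulforhodamine B assay; a higher number here means a weaker inhibitor of growth, a lower number a stronger inhibitor of growth. Going by the values given here, its only measured neighbour, compound 2 `CC1=CC[C@@H]([C@@](C)(O)CCCC(C)(C)NC(=S)N/N=C\c2cccc([N+](=O)[O-])c2)CC1`, gives 24700 nM in this assay, and the step of a 1.1-fold higher number from compound 1 to compound 2 (0.05 log units; within the scatter) shows that changing the aryl group on the carbon with a double bond to nitrogen left the number within the scatter. Compound 3 `CC1=CC[C@@H]([C@@](C)(O)CCCC(C)(C)NC(=S)N/N=C(/C)c2ccccc2)CC1` differs from compound 1 by a group of 9 heavy atoms (8 carbon, 1 nitrogen; one six-membered aromatic ring of carbon only) in place of a group of 10 heavy atoms (8 carbon, 1 nitrogen, 1 oxygen; one six-membered aromatic ring of carbon only), on an amide-type nitrogen. Among the compounds with values here, since the one step that bears on this site stayed within the scatter, compound 3 is expected to give 22000 nM, within the range 10000 nM to 50000 nM. The estimated step is a 1.0-fold lower number from compound 1 to compound 3 (0.00 log units; within the scatter), with no change beyond the scatter expected.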

Compound 3, concentration for total growth inhibition: 93300 nM
For compound 3 the middle estimate is 4.2-fold (0.63 log units) below the measured one; the whole stated range lies below it.
By their numbers in this assay, from the lowest: compounds 1 and 2 (each within the scatter of the next); then compound 3.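

In this assay the step of a 4.2-fold higher number from compound 1 to compound 3 (0.63 log units; beyond the scatter) shows that the group on the amide-type nitrogen can shift the number beyond the scatter, which the aryl swap from compound 1 to compound 2 did not show. Unlike that swap, this change also places a methyl on the carbon with a double bond to nitrogen, alongside a plain phenyl. Nothing available explains the shift. The compounds shown leave open whether the methyl or the loss of the methoxy carries the step, and how an ethyl on that carbon would behave.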